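This account rests on a few compounds, and the source may have more. Where it says the series, first, only, none or still open, it means among the compounds named here.

Measured set, each with its result in a functional assay on SW1573 cells (Homo sapiens) for cytotoxicity, read by sulforhodamine B assay, with a stated time of 72 h; a higher number here means a weaker inhibitor, a lower number a stronger inhibitor:
compound 1 `CCCCC(=O)Nc1ccn([C@@H]2CO[C@H](CO)O2)c(=O)n1`, 9130 nM;
compound 2 `CCCCCCCCCCCC(=O)Nc1ccn([C@@H]2CO[C@H](CO)O2)c(=O)n1`, 30 nM;
compound 3 `CCCCCCCCCCCCCCCCCCCC(=O)Nc1ccn([C@@H]2CO[C@H](CO)O2)c(=O)n1`, 150 nM.

Compound 1 gives the highest number of the three: the series shows a 300-fold lower number from compound 1 to compound 2 (2.48 log units; beyond the scatter) and then a 5.0-fold higher number from compound 2 to compound 3 (0.70 log units; beyond the scatter). Compound 4 `O=C(Nc1ccn([C@@H]2CO[C@H](CO)O2)c(=O)n1)C1CCCC1` differs from compound 1 by cyclopentyl in place of butyl on a carbonyl carbon. Among the measured compounds shown here, no measured step tests this change directly. Both known steps lengthen the chain, and the step from compound 1 to compound 2 is large, whereas compound 4 closes a ring rather than extending the chain. Only a small shift in this assay is therefore expected, likely within the scatter. For compound 4 the estimate is 6000 nM (range 2000 nM to 20000 nM), an expected step of a 1.5-fold lower number from compound 1 to compound 4 (0.18 log units; within the scatter).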

Compound 4, half-maximal inhibitory concentration: 8800 nM
Beside the measured number, compound 4's estimate is 1.5-fold (0.17 log units) below it; the measured number falls inside the stated range.
By their numbers in this assay, from the lowest: compound 2; then compound 3; then compounds 4 and 1 (each within the scatter of the next).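

In this assay, cyclopentyl in place of butyl on a carbonyl carbon gives a 1.0-fold lower number from compound 1 to compound 4 (0.02 log units; within the scatter), so a ring at this position leaves the number where the butyl group has it. The earlier steps shown here, both lengthening the chain, moved the number beyond the scatter; this one shows that a change of group here need not do so. Nothing at hand accounts for this result.

Open, from the compounds shown here alone, is whether a cyclohexyl or phenyl group would behave like cyclopentyl. Also open, going by these compounds, is whether a cyclopentyl ring at the end of a longer chain, or an amine on that chain, would keep the low number of compound 2 30 nM.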